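Bromo for methyl on the aromatic carbon: compound 3

The compounds below may be only part of what the source reports. "The series", "measured", "known", "first", "only" and "open" are said of these compounds alone.

Compound 1 `COC(=O)[C@@]1(C)CC[C@@H]2C3=C1CC[C@@H](C)[C@]3(C)Cc1c2[nH]c2ccccc12` is the parent of the pair measured so far; in a functional assay on WiDr cells (Homo sapiens) for inhibition, read by sulforhodamine B assay, with a stated time of 48 h (on this read-out lower numbers stand for stronger inhibition of growth and higher numbers for weaker inhibition of growth), compound 1 gives 4000 nM. Compound 2 `COC(=O)[C@@]1(C)CC[C@@H]2C3=C1CC[C@@H](C)[C@]3(C)Cc1c2[nH]c2ccc(C)cc12` carries a methyl on an aromatic carbon, and in this assay compound 2 gives 19000 nM. The step between them is a 4.8-fold higher number from compound 1 to compound 2 (0.68 log units; beyond the scatter). Among the compounds with values here, compound 2 therefore stands highest of the two numbers available, with compound 1 as its only neighbour.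

Compound 3 `COC(=O)[C@@]1(C)CC[C@@H]2C3=C1CC[C@@H](C)[C@]3(C)Cc1c2[nH]c2ccc(Br)cc12` is the next member: bromo in place of methyl on an aromatic carbon. Within the data shown here, no measured step exchanges bromo for methyl, or bromo for hydrogen, so the only step that bears on this change is a 4.8-fold higher number from compound 1 to compound 2 (0.68 log units; beyond the scatter), which concerns the same place but a different pair of groups. It shows that a substituent there can move the number beyond the scatter, but gives no direction for bromo relative to methyl. The expected step is a 1.3-fold lower number from compound 2 to compound 3 (0.10 log units; within the scatter) in this assay, which means no movement beyond the scatter in either direction. Compound 3 is estimated at 15000 nM, with a range from 5000 nM to 45000 nM.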

Compound 3, concentration for 50% growth inhibition: 22000 nM
The estimate for compound 3 lay 1.5-fold (0.17 log units) below the measured number; low and high end bracket the measured number.
By their numbers in this assay, from the lowest: compound 1; then compounds 2 and 3 (each within the scatter of the next).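

In this assay, bromo in place of methyl on this aromatic carbon gives a 1.2-fold higher number from compound 2 to compound 3 (0.06 log units; within the scatter) here, so the two groups cannot be told apart at this position. Bromo in place of hydrogen on the same carbon gives a 5.5-fold higher number from compound 1 to compound 3 (0.74 log units; beyond the scatter) and thus points the same way as a 4.8-fold higher number from compound 1 to compound 2 (0.68 log units; beyond the scatter) did for methyl, so the higher number relative to compound 1 now rests on two different groups rather than one, and neither compound 2 nor compound 3 goes against it. Nothing measured alongside these growth-inhibition numbers speaks to why a substituent at this carbon gives a higher number than hydrogen.

Left open is whether the same holds for a group of another kind on this carbon, such as a hydroxyl, an amine or a carboxylic acid, and whether any group there could give a lower number than compound 1 does. The compounds shown also leave open how the other aromatic carbons of this ring respond, and what happens when the methyl ester on the shared core is replaced by an amide or a carboxylic acid.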